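A Thiazole in Place of the Fluorophenyl Group

The compounds below may be only part of what the source reports. "The series", "measured", "known", "first", "only" and "open" are said of these compounds alone.

Of the compounds shown here, three of one series have been measured in a functional assay for agonist activity at G protein-coupled receptor 88 (Homo sapiens), read by HTRF and cAMP accumulation; on this read-out higher numbers stand for an effect only at larger amounts of compound and lower numbers for an effect already at smaller amounts. Among the compounds with values here, compound 1 `CO[C@H](C)[C@H](N)CN(C(=O)[C@@H]1C[C@H]1c1ccccc1)c1ccc(-c2ccccc2)cc1` gives 0.68 nM, and compound 2 `CCC(CC)C(N)CCN(C(=O)[C@@H]1C[C@H]1c1ccccc1)c1ccc(-c2ccccc2)cc1` gives 2 nM; the one change among them, a 2.9-fold higher number from compound 1 to compound 2 (0.47 log units; beyond the scatter), is the only step between measured compounds that differ in a single place. Compound 3 `CC[C@H](C)[C@H](N)CN(C(=O)[C@@H]1C[C@H]1c1ccccc1F)c1ccc(-c2ccccc2)cc1` gives 650 nM and so stands highest of the three numbers, far from both compound 1 and compound 2, with both gaps well beyond the scatter.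

The next compound, compound 4 `CC[C@H](C)[C@H](N)CN(C(=O)[C@@H]1C[C@H]1c1csc(C)n1)c1ccc(-c2ccccc2)cc1`, differs from compound 3 in one place: 2-methyl-1,3-thiazol-4-yl in place of 2-fluorophenyl on a saturated ring carbon. Within the data shown here, no measured step in this set touches the group on the three-membered ring; the only step seen, from compound 1 to compound 2, concerns the amino-bearing chain and says nothing about this exchange. The expectation for compound 4 therefore rests on compound 3 alone, and the size and direction of the step cannot be anticipated from the data; the estimated step is a 1.1-fold lower number from compound 3 to compound 4 (0.03 log units; within the scatter), which is no step beyond the scatter. In this assay, compound 4 is expected to give about 600 nM, with a range from 120 nM to 3000 nM.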

Compound 4, half-maximal effective concentration: 1500 nM
Beside the measured number, compound 4's estimate is 2.5-fold (0.40 log units) below it; low and high end bracket the measured number.
By their numbers in this assay, from the lowest: compound 1; then compound 2; then compound 3; then compound 4.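

In this assay, within the data shown here, the exchange of 2-fluorophenyl for 2-methyl-1,3-thiazol-4-yl gives a 2.3-fold higher number from compound 3 to compound 4 (0.36 log units; beyond the scatter) and is the first measured step at this position, on a saturated ring carbon of the three-membered ring. It shows that a five-membered aromatic ring with 2 hetero atoms can stand here in place of a six-membered aromatic ring of carbon only, at a modest cost in the number, even though the entering group brings 2 hydrogen-bond acceptors and the leaving group none. No measurement shown bears on the reason for this step.

From the compounds shown here alone, what remains open is how a plain phenyl, a pyridin-2-yl group or a 1,3-thiazol-4-yl group without the methyl would read at this position on the same amino-bearing chain, so the separate shares of the fluorine, the methyl and the ring exchange cannot be told apart. Also open, going by these compounds, is whether the same exchange would give a step of similar size and direction on the methoxy-bearing chain of compound 1, where the number is far lower.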